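This account rests on a few compounds, and the source may have more. Where it says the series, first, only, none or still open, it means among the compounds named here.

Measured compounds:
Compound 1, `CCc1c(CC2CCCCC2)nc(SCC(=O)c2ccccc2)[nH]c1=O`, gives 0.012 nM in an ADME assay on C1866 cells (Homo sapiens) for cytotoxicity, read by MTT assay, with a stated time of 72 h; on this read-out higher numbers stand for an effect only at larger amounts of compound and lower numbers for an effect already at smaller amounts.
Compound 2, `CCc1c(CC2CCCCC2)nc(SCc2ccccc2)[nH]c1=O`, gives 532 nM in this assay.
Compound 3, `Cc1c(CC2CCCCC2)nc(SCC(=O)c2ccccc2)[nH]c1=O`, gives 75.8 nM in this assay.

The step from compound 1 to compound 2 is the change (phenyl in place of benzoyl on a saturated chain carbon bound to a sulfur), and it made a 44000-fold higher number from compound 1 to compound 2 (4.65 log units; beyond the scatter). Compound 4, `Cc1c(CC2CCCCC2)nc(SCc2ccccc2)[nH]c1=O`, is not yet measured; it arises from compound 3 by the same change, (phenyl in place of benzoyl on a saturated chain carbon bound to a sulfur). The two cores differ by hydrogen in place of methyl on a saturated chain carbon bound to an aromatic carbon, a change that alone made a 6300-fold higher number from compound 1 to compound 3 (3.80 log units; beyond the scatter). For compound 4 I expect a smaller step, a 26-fold higher number from compound 3 to compound 4 (1.42 log units; beyond the scatter), because compound 2 gives 532 nM and compound 4 differs from it only by that core change, while compound 1's 0.012 nM stands far apart from both other compounds. Compound 4 is therefore estimated at 2000 nM, likely between 300 nM and 30000 nM.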

Compound 4, half-maximal effective concentration: 1250 nM
Estimate against measurement, compound 4: 1.6-fold (0.20 log units) above; low and high end bracket the measured number.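

In this assay, phenyl in place of benzoyl on a saturated chain carbon bound to a sulfur again gives a higher number, a 16-fold higher number from compound 3 to compound 4 (1.22 log units; beyond the scatter), but the size of the step does not carry over from one core to the other: the same change on two cores in this assay, a 44000-fold higher number (4.65 log units; beyond the scatter) from compound 1 to compound 2 and a 16-fold higher number (1.22 log units; beyond the scatter) from compound 3 to compound 4, 2700-fold (3.43 log units) apart, beyond the scatter of two such steps

Hydrogen in place of methyl on a saturated chain carbon bound to an aromatic carbon also gives a higher number again, a 2.3-fold higher number from compound 2 to compound 4 (0.37 log units; beyond the scatter), and here too the size does not carry over: the same change on two cores in this assay, a 6300-fold higher number (3.80 log units; beyond the scatter) from compound 1 to compound 3 and a 2.3-fold higher number (0.37 log units; beyond the scatter) from compound 2 to compound 4, 2700-fold (3.43 log units) apart, beyond the scatter of two such steps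

Across these four compounds the direction of each change held while its size did not, but they do not show why, or whether this extends to other cores.

Still open, going by these compounds, is how an amide or a carboxylic acid would read in place of benzoyl on that chain carbon. A longer chain in place of the methyl is open as well.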